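Side chain variation on the amino-quinone series

A few compounds are considered here, and "the series" means these few. Any claim that something is new, unique, unknown or untested is made for them only; others in the source may bear on it.

Compound 1 `C=C1[C@H](C)CCC[C@]1(C)CC/C(C)=C/CC1=C(O)C(=O)C=C(N[C@@H](C(=O)O)[C@H](C)O)C1=O` gives 4.6 ug/mL in an ADME assay on L1210 cells (Mus musculus) for cytotoxicity, with a stated time of 48 h; on this read-out lower numbers stand for stronger inhibition and higher numbers for weaker inhibition. Compound 2 `C=C1[C@H](C)CCC[C@]1(C)CC/C(C)=C/CC1=C(O)C(=O)C=C(N[C@@H](CO)C(=O)O)C1=O` reaches only > 10 ug/mL in this assay, which is a limit of the assay and not a number. Going by the values given here, the one measured step, an at least 2.1-fold higher number from compound 1 to compound 2 (0.33 log units; beyond the scatter), is bounded by the limit of > 10 ug/mL in this assay, at which 1 of the 2 values shown sits. Compound 3 `C=C1[C@H](C)CCC[C@]1(C)CC/C(C)=C/CC1=C(O)C(=O)C=C(N[C@@H](C(=O)O)C(C)C)C1=O` carries 1-carboxy-2-methylpropyl in place of 1-carboxy-2-hydroxyethyl on an amine nitrogen. Because an at least 2.1-fold higher number from compound 1 to compound 2 (0.33 log units; beyond the scatter) accompanied 1-carboxy-2-hydroxyethyl in place of 1-carboxy-2-hydroxypropyl, the larger 1-carboxy-2-methylpropyl is expected to return a lower number. The expected step is an at least 2.0-fold lower number from compound 2 to compound 3 (0.30 log units; that floor lies within the scatter) in this assay. Compound 3 is estimated at 5 ug/mL, between 2 ug/mL and 12 ug/mL.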

Compound 3, half-maximal inhibitory concentration: 3.4 ug/mL
For compound 3 the middle estimate is 1.5-fold (0.17 log units) above the measured one; low and high end bracket the measured number.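

At this amine nitrogen, a side chain without a hydroxyl is tolerated: in this assay the change gives an at least 2.9-fold lower number from compound 2 to compound 3 (0.46 log units; beyond the scatter). On these data alone, compound 2 stands at a limit of the assay and not at a number, so the true size of that step stays unknown: the limit of > 10 ug/mL in this assay, at which 1 of the 3 values shown sits. Isopropyl in place of 1-hydroxyethyl gives a 1.4-fold lower number from compound 1 to compound 3 (0.13 log units; within the scatter), so the hydroxyl on this chain is not required to reach the level of compound 1.

As far as these compounds go, it remains open whether a longer chain such as 2-methylbutyl, or an amine on this chain, would hold that level.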